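Moving one hydroxyl: from 4-hydroxyphenyl to 2-hydroxyphenyl

This account rests on a few compounds, and the source may have more. Where it says the series, first, only, none or still open, it means among the compounds named here.

Compound 1 `CCCCCCCCCCOc1cccc(O)c1C(=O)/C=C/c1ccc(O)cc1` gives > 30000 nM as a limit
Compound 2 `CCCCCCCCCCCCOc1cccc(O)c1C(=O)/C=C/c1ccc(O)cc1` gives > 30000 nM as a limit
Compound 3 `CCCCCCCCCCCCCCCCOc1cccc(O)c1C(=O)/C=C/c1ccc(O)cc1` gives > 30000 nM as a limit

All three values come from an ADME assay on RAW264.7 cells (Mus musculus) for cytotoxicity, read by MTT assay (on this read-out lower numbers stand for stronger inhibition and higher numbers for weaker inhibition), and none of them is an exact number. Compound 1 therefore has no precise place on the scale, and what the data offer is the limit of > 30000 nM in this assay, at which 3 of the 3 values shown sit, and nothing finer.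

Compound 4 `CCCCCCCCCCOc1cccc(O)c1C(=O)/C=C/c1ccccc1O` has not been measured yet. Going by the values given here, it keeps the core of compound 1 and the same chain, and the one change is 2-hydroxyphenyl in place of 4-hydroxyphenyl on a double-bonded chain carbon bound to a double-bonded chain carbon in the group on the double-bonded chain carbon.

The measured steps alter only the chain and leave this group untouched. They are a step that the two limits leave unreadable from compound 1 to compound 2 and a step that the two limits leave unreadable from compound 1 to compound 3 and a step that the two limits leave unreadable from compound 2 to compound 3 and none of them has a readable size to carry over.

Among the compounds with values here, the only anchor for compound 4 is compound 1 at > 30000 nM as a limit. No shift beyond the scatter can be argued from this, so the expected size of the change is a number no higher from compound 1 to compound 4 (the limit leaves the size open) in all likelihood. Another limit is the most likely report. The estimate for compound 4 is 30000 nM with 12000 nM to 60000 nM as its expected range.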

Compound 4, half-maximal inhibitory concentration: > 30000 nM
Compound 4: a limit, no number; the forecaster's own chance of this, stated with the estimate: 70%; the middle value lies on the limit itself.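

In this assay compound 4 gives > 30000 nM, which is a limit and not a number. Compound 1 also stands at a limit, and no step can be read between compound 1 and compound 4. The compounds shown leave open where any of them would fall as an exact number, and whether 2-hydroxyphenyl in place of 4-hydroxyphenyl changes it at all.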